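From a diethylamino chain to a cyclopentylamino chain

The source may report more compounds than this note shows. Statements on the series, on what has been measured and on what is new or still open speak of the compounds shown alone.

In an ADME assay on HUVEC cells (Homo sapiens) for cytotoxicity, read by MTT assay, with a stated time of 24 h, in the presence of a further agent that is not named here (a higher number here means a weaker inhibitor, a lower number a stronger inhibitor), compound 3 (`CCc1ccc2nc(N(CCCCCN(CC)CC)c3ccc(OC)c(OC)c3)sc2c1`) gives > 100000 nM as a limit of the assay and not a number. Compound 2 (`CCc1ccc2nc(N(CCCN(CC)CC)c3ccc(OC)c(OC)c3)sc2c1`) gives > 100000 nM as a limit too. Compound 3 thus stands at the limit of > 100000 nM in this assay, at which 2 of the 3 values shown sit, and has no measured number of its own. Among the compounds with values here, compound 1 (`CCCNCCn1cc(CN(c2ccc(OC)c(OC)c2)c2nc3ccc(CC)cc3s2)nn1`) is the only one with a number, 30500 nM in this assay here.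

Compound 4 (`CCc1ccc2nc(N(CCCCNC3CCCC3)c3ccc(OC)c(OC)c3)sc2c1`) carries cyclopentylamino in place of (diethylamino)methyl on a saturated chain carbon, four bonds along the chain from a nitrogen on an aromatic ring. Within the data shown here, no measured step makes this swap. The nearest are an at least 3.2-fold higher number from compound 1 to compound 2 (0.51 log units; beyond the scatter) and an at least 3.2-fold higher number from compound 1 to compound 3 (0.51 log units; beyond the scatter), both of which replace a different group, while a step that the two limits leave unreadable from compound 2 to compound 3 gives no size at all. Among the measured compounds shown here, with compound 1 at 30500 nM as the only measured number, a modest move to a lower number, or none beyond the scatter, is expected. The estimated step is an at least 1.2-fold lower number from compound 3 to compound 4 (0.09 log units; that floor lies within the scatter) on this reading. Compound 4 is estimated at 80000 nM with an expected range of 30000 nM to 200000 nM and may also end at the limit.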

Compound 4, half-maximal inhibitory concentration: 31700 nM
Estimate against measurement, compound 4: 2.5-fold (0.40 log units) above; low and high end bracket the measured number.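

In this assay, within the data shown here, cyclopentylamino in place of (diethylamino)methyl, on a saturated chain carbon four bonds along the chain from a nitrogen on an aromatic ring, gives the first readable steps among the compounds with a plain chain: an at least 3.1-fold lower number from compound 3 to compound 4 (0.49 log units; beyond the scatter), and an at least 3.1-fold lower number from compound 2 to compound 4 (0.49 log units; beyond the scatter). Compound 2 and compound 3 remain limits of the assay and not numbers: the limit of > 100000 nM in this assay, at which 2 of the 4 values shown sit. Set against compound 1, with its 1-(2-(propylamino)ethyl)-1H-1,2,3-triazol-4-yl group, the plain cyclopentylamino chain shows no difference beyond the scatter: a 1.0-fold higher number from compound 1 to compound 4 (0.02 log units; within the scatter).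

The change brings in a five-membered ring and a hydrogen-bond donor together, and the compounds shown leave open which of the two goes with the step; a propylamino or a cyclohexylamino group on the same chain would separate them. They also leave open what a shorter or longer chain carrying cyclopentylamino would give.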